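Swapping a methoxy for a methyl on the side chain

The compounds below may be only part of what the source reports. "The series", "measured", "known", "first", "only" and "open" are said of these compounds alone.

Compound 1 `COCC(C(=O)N1CCN(c2cccc(C(F)(F)F)c2)CC1)N1C(=O)CCC1=O` and compound 2 `CC(C(=O)N1CCN(c2ccccc2C(F)(F)F)CC1)N1C(=O)CCC1=O` were both tested in a functional assay on the whole organism (strain Swiss) with Mus musculus as the target, in the maximal electroshock model, with a stated time of 0.25 h, at a dose of 100 mg/kg by the intraperitoneal route; on this read-out higher numbers stand for a stronger effect at the one dose given and lower numbers for a weaker effect. In that test compound 1 gives 100%, and compound 2 gives 100%, so the two stand level at the digits shown, within the usual scatter of this kind of measurement. On the numbers available, compound 1 therefore sits at the top of what this assay can report, with no measured neighbour lying above or below it.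

Compound 3 `CCC(C(=O)N1CCN(c2cccc(C(F)(F)F)c2)CC1)N1C(=O)CCC1=O` is the next structure, and it differs from compound 1 in one place: methyl in place of methoxy on a saturated chain carbon, two bonds along the chain from an amide-type nitrogen in a ring and a carbonyl carbon. For the measured compounds named here, no measured pair in this set shows such a change, so there is no direct guide to its size. With compound 1 measured at 100%, the step is expected to be none beyond the scatter, downward if anything, giving no change at the digits printed from compound 1 to compound 3 (within the scatter). Compound 3 is thus estimated at 100%, within a range from 75% to 100%.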

Compound 3, a percentage reported as activity, at one dose (the size of the read-out at that dose, not a potency): 75%
Beside the measured number, compound 3's estimate is 25 percentage points above it; the measured number falls inside the stated range.
By their numbers in this assay, from the lowest: compound 3; then compounds 1 and 2 (each within the scatter of the next).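

Side-chain substitution matters in this assay: with methyl in place of methoxy on a saturated chain carbon, two bonds along the chain from an amide-type nitrogen in a ring and a carbonyl carbon, the read-out shows a number 25 percentage points lower from compound 1 to compound 3 (beyond the scatter), a modest loss at the one dose given. The earlier compounds shown here could not show this, as they stood level and differed in more than one place. No measurement here bears on why the read-out falls with this change.

This single pair leaves open whether the oxygen or the chain itself accounts for the difference, and a hydroxymethyl, an aminomethyl or a longer chain such as propyl on the same carbon would help separate these. A single dose also leaves open how the two compounds would compare at lower doses.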